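The compounds below may be only part of what the source reports. "The series", "measured", "known", "first", "only" and "open" are said of these compounds alone.

Measured so far:
- compound 1, `CCC(=O)Nc1cccc(Oc2nc(Nc3ccc(N4CCCC4)cc3OC)ncc2Cl)c1`: 25.8%
- compound 2, `CCC(=O)Nc1cccc(Oc2nc(Nc3ccc(N4CCC(C)CC4)cc3OC)ncc2Cl)c1`: 9.2%
- compound 3, `CCC(=O)Nc1cccc(Oc2nc(Nc3ccc(N4CCC(C)CC4)cc3)ncc2Cl)c1`: 13.4%

All three numbers come from an assay on isolated protein for inhibition of NUAK family SNF1-like kinase 1 (Homo sapiens), read by ADP-Glo, with a stated time of 60 min, tested at 10 uM, in the presence of a further agent that is not named here; on this read-out higher numbers stand for more inhibition at the one concentration tested (going by the name of the read-out) and lower numbers for less inhibition. Within the set, compound 3 stands second highest; next to it is compound 2, within the scatter, and furthest from it is compound 1, beyond the scatter.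

Two single changes are measured. From compound 2 to compound 1 the change is pyrrolidin-1-yl in place of 4-methylpiperidin-1-yl on an aromatic carbon and the step it made is a number 16.6 percentage points higher from compound 2 to compound 1 (beyond the scatter). The cores of compound 2 and compound 3 differ by hydrogen in place of methoxy on an aromatic carbon, with the step of a number 4.2 percentage points higher from compound 2 to compound 3 (within the scatter), which is within the scatter.

Compound 4, `CCC(=O)Nc1cccc(Oc2nc(Nc3ccc(N4CCCC4)cc3)ncc2Cl)c1`, is not yet measured. It differs from compound 3 by pyrrolidin-1-yl in place of 4-methylpiperidin-1-yl on an aromatic carbon. This is the same kind of change as that from compound 2 to compound 1, not the same: in compound 2 the place is also "meta to a methoxy group", whereas in compound 3 that methoxy is absent. The expected step is a number 12.6 percentage points higher from compound 3 to compound 4 (beyond the scatter), somewhat tempered relative to the earlier one and resting on compound 2 and its step of a number 16.6 percentage points higher from compound 2 to compound 1 (beyond the scatter) together with the small core difference a number 4.2 percentage points higher from compound 2 to compound 3 (within the scatter). For compound 4 in this assay the estimate is 26%, between 12% and 40%.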

Compound 4, a percentage reported as inhibition, at one concentration (the size of the read-out at that concentration, not a potency): "not active" (no number reported)
Compound 4 has no reported number here, so the estimate cannot be set against anything.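

Going by these compounds alone, compound 4 is recorded as "not active" in this assay with no number, so no step from compound 3 to compound 4 can be read. Nothing measured here bears on this result. The compounds shown leave open how pyrrolidin-1-yl in place of 4-methylpiperidin-1-yl acts on the core lacking methoxy.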